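The compounds below may be only part of what the source reports. "The series", "measured", "known", "first", "only" and "open" are said of these compounds alone.

Of the compounds shown here, three that share one core have been measured in an assay on isolated protein for binding affinity to leukotriene B4 receptor 1 (Homo sapiens), tested at 1 uM; on this read-out higher numbers stand for more inhibition at the one concentration tested (going by the name of the read-out) and lower numbers for less inhibition. Compound 1 `CCc1cc(C(C)=O)c(O)cc1OCCCC(C)(C)C#N` gives 46%. Compound 2 `CCc1cc(C(C)=O)c(O)cc1OCCCCCCCC(C)(C)C#N` gives 29%. Compound 3 `CCc1cc(C(C)=O)c(O)cc1OCCCCCC[S+](C)[O-]` gives 50%, the highest of the three numbers shown, although its difference from compound 1 lies within the scatter, a number 4 percentage points higher from compound 1 to compound 3 (within the scatter), while its difference from compound 2 lies beyond it, a number 21 percentage points higher from compound 2 to compound 3 (beyond the scatter). Compound 4 `CCc1cc(C(C)=O)c(O)cc1OCCCCCCS(C)(=O)=O` has not yet been measured. It differs from compound 3 in one place: a group of 4 heavy atoms (1 carbon, 2 oxygen, 1 sulfur; no ring) in place of a group of 3 heavy atoms (1 carbon, 1 oxygen, 1 sulfur; no ring), on a saturated chain carbon, six bonds along the chain from an oxygen on an aromatic ring. Both measured steps that lead to compound 3 also exchange the group at the end of the chain, and the one that sits at the same place, six bonds along the chain from the oxygen on the aromatic ring, moved the number by a modest amount. Neither of them exchanges one sulfur-bearing group for another, so they bear only loosely on the present change. The expectation is therefore for no step beyond the scatter in this assay, a number 5 percentage points lower from compound 3 to compound 4 (within the scatter). Compound 4 is estimated to give 45% in this assay, with a range from 28% to 62%.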

Compound 4, a percentage reported as inhibition, at one concentration (the size of the read-out at that concentration, not a potency): 62%
The estimate for compound 4 lay 17 percentage points below the measured number; the range from low to high includes it.
By their numbers in this assay, from the lowest: compound 2; then compounds 1 and 3 (each within the scatter of the next); then compound 4.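

Within the data shown here, at the saturated chain carbon six bonds along the chain from the oxygen on the aromatic ring, exchanging one sulfur-bearing end group for another does change the result in this assay: methylsulfonyl in place of the group in compound 3 gives a number 12 percentage points higher from compound 3 to compound 4 (beyond the scatter) and so moves the number past the usual scatter, which no earlier step between sulfur groups could show. Compound 4 also stands clear of both nitrile-bearing compounds, with a number 33 percentage points higher from compound 2 to compound 4 (beyond the scatter) for methylsulfonyl in place of 2-cyano-2-methylpropyl and a number 16 percentage points higher from compound 1 to compound 4 (beyond the scatter) for 3-(methylsulfonyl)propyl in place of 1-cyano-1-methylethyl, whereas compound 3 stood clear only of compound 2, so compound 4 alone has steps beyond the scatter to all the others. Nothing shown here accounts for these steps.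

Methylsulfonyl appears on only one chain, so a shorter or longer chain carrying it, or a sulfonamide or a carboxylic acid at the same place, remains an open question. From the compounds shown here alone, each number also comes from a single tested concentration, so how far these steps would carry over to a true potency remains unknown.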